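Amine-nitrogen substituent swap on the shared core: cytotoxicity outlook

A few compounds are considered here, and "the series" means these few. Any claim that something is new, unique, unknown or untested is made for them only; others in the source may bear on it.

In an ADME assay on L6 cells (Rattus norvegicus) for cytotoxicity (on this read-out lower numbers stand for stronger inhibition and higher numbers for weaker inhibition), compound 1 `CN1CCN(CC(=O)N2CCC3(N4CCCC4)CC(c4ccccc4)C2C(c2ccccc2)C3)CC1` gives 69100 nM, the second highest of the three numbers. Compound 2 `c1ccc(C2CC3(N4CCCCC4)CC(NCN4CCCC4)C2C(c2ccccc2)C3)cc1` gives 43000 nM, within the scatter of compound 1. Going by the values given here, compound 3 `CN1CCN(CC(=O)N2CCC3(N4CCCCC4)CC(c4ccccc4)C2C(c2ccccc2)C3)CC1` gives 177000 nM, and the step of a 2.6-fold higher number from compound 1 to compound 3 (0.41 log units; beyond the scatter) is the only single-point change measured so far. Compound 4 `c1ccc(C2CC3(N4CCCC4)CCN(CCCN4CCCCC4)C2C(c2ccccc2)C3)cc1` differs from compound 1 elsewhere: 3-(piperidin-1-yl)propyl in place of ((4-methylpiperazin-1-yl)methyl)carbonyl on an amine nitrogen in a ring. Among the compounds with values here, no measured step touches the amine nitrogen in the ring, and the one known step concerns pyrrolidin-1-yl against piperidin-1-yl on a saturated ring carbon, so it offers no direct guide. Compound 4 is therefore estimated at 40000 nM, with a wide range from 10000 nM to 150000 nM. The step of a 1.7-fold lower number from compound 1 to compound 4 (0.24 log units; within the scatter) is expected to be modest at most, with low confidence.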

Compound 4, half-maximal inhibitory concentration: 28700 nM
Beside the measured number, compound 4's estimate is 1.4-fold (0.14 log units) above it; the measured number falls inside the stated range.
By their numbers in this assay, from the lowest: compounds 4, 2 and 1 (each within the scatter of the next, the first and the last beyond it); then compound 3.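

In this assay the amine nitrogen in the ring responds to substitution, with a 2.4-fold lower number from compound 1 to compound 4 (0.38 log units; beyond the scatter) when 3-(piperidin-1-yl)propyl replaces ((4-methylpiperazin-1-yl)methyl)carbonyl. The earlier single-place step lay on a saturated ring carbon, so this is a second position where a change goes beyond the scatter, here towards a lower number rather than a higher one. No measured evidence accounts for this step.

The swap removes the carbonyl and changes the ring and chain together, so this one step cannot assign the shift to any one of them. On these data alone, how a morpholin-4-yl group at the end of the propyl chain, or a longer chain, would read here stays open.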